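The compounds below may be only part of what the source reports. "The series", "measured", "known", "first", "only" and "open" are said of these compounds alone.

Compound 1 `COc1ccc(C(=O)c2ccc(OC)c3c2C=CC(C)(C)O3)c(NC(=O)CN)c1`: 890 nM
Compound 2 `COc1ccc(C(=O)c2ccc3c(c2)C=CC(C)(C)O3)c(NC(=O)CN)c1`: 590 nM
Compound 3 `CNCC(=O)Nc1cc(OC)ccc1C(=O)c1ccc(OC)c2c1C=CC(C)(C)O2`: 1590 nM

These three were measured in a functional assay on A2780 cells (Homo sapiens) for antiproliferative activity, read by MTT assay, with a stated time of 48 h; a lower number here means a stronger inhibitor, a higher number a weaker inhibitor. Compound 3 differs from compound 1 in one place, (methyl in place of hydrogen on an amine nitrogen), and that change gave a step of a 1.8-fold higher number from compound 1 to compound 3 (0.25 log units; within the scatter). The values of compound 1 and compound 2 lie within the scatter of each other, while compound 3 lies beyond the scatter from compound 2. The difference between the cores of compound 1 and compound 2 is not broken down here.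

Compound 4 `CNCC(=O)Nc1cc(OC)ccc1C(=O)c1ccc2c(c1)C=CC(C)(C)O2` carries the same change against compound 2, (methyl in place of hydrogen on an amine nitrogen); the surroundings of the place are the same in both pairs, so it is the same change. In this assay the step is expected to be a 1.8-fold higher number from compound 2 to compound 4 (0.25 log units; within the scatter) because a 1.8-fold higher number from compound 1 to compound 3 (0.25 log units; within the scatter) stayed within the scatter. Compound 4 is therefore estimated at 1050 nM, expected between 500 nM and 2200 nM.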

Compound 4, half-maximal inhibitory concentration: 850 nM
For compound 4 the middle estimate is 1.2-fold (0.09 log units) above the measured one; the measured number falls inside the stated range.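

In this assay methyl in place of hydrogen on an amine nitrogen gives a 1.4-fold higher number from compound 2 to compound 4 (0.16 log units; within the scatter) on the core of compound 2, and this agrees with the step on the core of compound 1: the same change on two cores in this assay, a 1.8-fold higher number (0.25 log units; within the scatter) from compound 1 to compound 3 and a 1.4-fold higher number (0.16 log units; within the scatter) from compound 2 to compound 4, 1.2-fold (0.09 log units) apart, within the scatter of two such steps. The change therefore carries across these two cores without a difference that can be told from the scatter. Going by these compounds alone, since each step itself lies within the scatter, this shows only that the change has no clear effect on either core, and it says nothing of other cores.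

Still open, going by these compounds, is whether an ethylamino or dimethylamino group would give a step beyond the scatter on either core. The same holds for a longer chain carrying the amine.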